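The source may report more compounds than this note shows. Statements on the series, on what has been measured and on what is new or still open speak of the compounds shown alone.

Compound 1 `CCS(=O)(=O)N1CCC2(CC1)OOC1(CCCCC1)OO2` has been tested in a functional assay on Huh-7 cells (Homo sapiens) for cytotoxicity, read by MTT assay, with a stated time of 72 h; a lower number here means that less compound is tolerated, a higher number that more compound is tolerated. In this test compound 1 gives > 100 ug/mL as its result, which is a limit of the assay and not a number. Compound 2 `O=S(=O)(Cc1ccccc1)N1CCC2(CC1)OOC1(CCCC1)OO2` carries a different group on the sulfonyl sulfur and gives > 100 ug/mL as its result, again only a limit. For the measured compounds named here, the evidence so far is therefore the limit of > 100 ug/mL in this assay, at which 2 of the 2 values shown sit, and no measured step yet shows how much a change on the sulfonyl sulfur can matter. Going by the values given here, compound 3 `O=S(=O)(c1ccc(F)cc1)N1CCC2(CC1)OOC1(CCCCC1)OO2` keeps the core of compound 1 and has 4-fluorophenyl in place of ethyl on a sulfonyl sulfur as its one change. The expected step of a number no higher from compound 1 to compound 3 (the limit leaves the size open) in this assay is no larger than the usual scatter, and another result reported only as a limit is likely. This expectation leans on compound 2 with its limit of > 100 ug/mL in a case where the group on the sulfonyl sulfur also holds an aromatic ring. For compound 3 the estimated value is 100 ug/mL with an expected range from 40 ug/mL to 200 ug/mL in this test.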

Compound 3, half-maximal cytotoxic concentration: > 100 ug/mL
Compound 3: no number, only a limit; the forecaster's own chance of this, stated with the estimate: 65%; the middle value lies on the limit itself.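

In this assay compound 3 gives > 100 ug/mL as its result, which is a limit and not a number. Compound 1 also has only a limit, so no step can be read between compound 1 and compound 3, and the picture stays as it was: the limit of > 100 ug/mL in this assay, at which 3 of the 3 values shown sit.

The compounds shown leave open how much any change on the sulfonyl sulfur can matter in this test.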